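Swapping Methylsulfonyl for tert-Butyl on the Sulfonamide Ring

The source may hold more compounds than are shown below. What is called first, only, known or untested is meant among the compounds shown, and "the series" means these compounds.

Of the compounds shown here, three built on one shared core have been tested in a functional assay on PC-3 cells (Homo sapiens) for inhibition; a lower number here means a stronger inhibitor, a higher number a weaker inhibitor. Compound 1 `COc1cc2nc(N3CCN(S(=O)(=O)c4ccc(Cl)s4)CC3)nc(N)c2cc1OC` gives 25000 nM in this assay. Compound 2 `COc1cc2nc(N3CCN(S(=O)(=O)c4ccc(C)cc4)CC3)nc(N)c2cc1OC` gives 30000 nM, and compound 3 `COc1cc2nc(N3CCN(S(=O)(=O)c4ccc(S(C)(=O)=O)cc4)CC3)nc(N)c2cc1OC` gives 17000 nM. Compound 3 shows the lowest of the three numbers, yet its separations from the others are small: a 1.5-fold lower number from compound 1 to compound 3 (0.17 log units; within the scatter) and a 1.8-fold lower number from compound 2 to compound 3 (0.25 log units; within the scatter), both within the usual scatter, so no ranking among the three can be claimed. The step of a 1.2-fold higher number from compound 1 to compound 2 (0.08 log units; within the scatter) is likewise within the scatter.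

Compound 4 `COc1cc2nc(N3CCN(S(=O)(=O)c4ccc(C(C)(C)C)cc4)CC3)nc(N)c2cc1OC` differs from compound 3 in one place: tert-butyl in place of methylsulfonyl on an aromatic carbon. Among the measured compounds shown here, the measured step that bears most directly on this change is the one from compound 2 to compound 3, where a methyl became a methylsulfonyl at this same position and the number moved only a 1.8-fold lower number from compound 2 to compound 3 (0.25 log units; within the scatter). The expected step of a 1.5-fold higher number from compound 3 to compound 4 (0.17 log units; within the scatter) is therefore small, not beyond the scatter, because the related step of a 1.8-fold lower number from compound 2 to compound 3 (0.25 log units; within the scatter) was itself within the scatter. Compound 4 is estimated at 25000 nM, within a range from 10000 nM to 60000 nM.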

Compound 4, half-maximal inhibitory concentration: 4100 nM
Beside the measured number, compound 4's estimate is 6.1-fold (0.79 log units) above it, outside the stated range (below it).
By their numbers in this assay, from the lowest: compound 4; then compounds 3, 1 and 2 (each within the scatter of the next).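

Among the earlier compounds, no change at this aromatic carbon moved the number beyond the scatter, but in this assay there is now a 4.1-fold lower number from compound 3 to compound 4 (0.62 log units; beyond the scatter) for tert-butyl in place of methylsulfonyl. The same group also separates compound 4 from the other two, with a 7.3-fold lower number from compound 2 to compound 4 (0.86 log units; beyond the scatter) for tert-butyl in place of methyl and a 6.1-fold lower number from compound 1 to compound 4 (0.79 log units; beyond the scatter) for the 4-(tert-butyl)phenyl exchange, so all three steps are modest but beyond the scatter. Methylsulfonyl and tert-butyl match in heavy-atom count, so that count does not separate them, and no measured evidence here accounts for the step. The compounds shown leave open whether this result is particular to tert-butyl or extends to other carbon groups such as isopropyl or cyclohexyl. Going by these compounds, how an amine or a carboxylic acid at the same carbon would compare also remains unknown.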